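The source may hold more compounds than are shown below. What is called first, only, known or untested is meant among the compounds shown, and "the series" means these compounds.

Compound 3 `O=C(Nc1nc2ccccc2s1)c1cn(-c2ccccc2)nc1-c1ccc(Cl)cc1` gives 7750 nM in a functional assay on PC-3 cells (Homo sapiens) for cytotoxicity, read by MTT assay, with a stated time of 72 h; a higher number here means a weaker inhibitor, a lower number a stronger inhibitor. Among the three numbers in hand it is the second highest: compound 2 `O=C(Nc1nc2ccccc2s1)c1cn(-c2ccccc2)nc1-c1ccc(F)cc1` gives 7130 nM, and compound 1 `O=C(Nc1nc2ccccc2s1)c1cn(-c2ccccc2)nc1-c1ccccc1` gives 10400 nM. The measured steps are all small: a 1.5-fold lower number from compound 1 to compound 2 (0.16 log units; within the scatter), a 1.3-fold lower number from compound 1 to compound 3 (0.13 log units; within the scatter) and a 1.1-fold higher number from compound 2 to compound 3 (0.04 log units; within the scatter), each within the scatter.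

The next compound, compound 4 `Cc1ccc2nc(NC(=O)c3cn(-c4ccccc4)nc3-c3ccc(Cl)cc3)sc2c1`, differs from compound 3 by methyl in place of hydrogen on an aromatic carbon. Among the measured compounds shown here, every measured step so far concerns a halogen in place of hydrogen, or a halogen for a halogen, on an aromatic carbon of a different part of the molecule; none of them touches the ring that carries the new methyl. For the measured compounds named here, there is therefore no step that bears directly on this change. Given that all three measured steps stayed within the scatter, the expectation for compound 4 in this assay is likewise no step beyond the scatter, a 1.1-fold lower number from compound 3 to compound 4 (0.04 log units; within the scatter). The estimate for compound 4 is 7000 nM, with a range from 3500 nM to 14000 nM.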

Compound 4, half-maximal inhibitory concentration: 14500 nM
Compound 4: middle estimate off by 2.1-fold (0.32 log units), on the low side, and the stated range ends below it.
By their numbers in this assay, from the lowest: compounds 2, 3, 1 and 4 (each within the scatter of the next, the first and the last beyond it).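

The 6-methyl-1,3-benzothiazol-2-yl group of compound 4 is the first change shown at this end of the molecule, where the earlier steps offered no reading. In this assay methyl in place of hydrogen on this aromatic carbon gives a 1.9-fold higher number from compound 3 to compound 4 (0.27 log units; within the scatter) and so, like the halogen changes elsewhere on the molecule, this single change stays within the scatter. Nothing at hand accounts for the size of this step.

One methyl does not define this position: an amine, a methoxy group, a carboxylic acid or a longer chain in the same place could give a different reading. Going by these compounds, it also remains open whether the methyl would give a similar step on the core of compound 1 or compound 2, which carry hydrogen and fluoro in place of the chloro of compound 3.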